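Ketone aryl group variation toward compound 4

A few compounds are considered here, and "the series" means these few. Any claim that something is new, unique, unknown or untested is made for them only; others in the source may bear on it.

Compound 1 `O=C(/C=C/c1cccc(OCc2ccccc2)c1)c1ccccc1Br` gives 61200 nM in a functional assay on PANC-1 cells (Homo sapiens) for cytotoxicity, read by MTT assay, with a stated time of 68 h (a higher number here means a weaker inhibitor, a lower number a stronger inhibitor), the highest of the three numbers in hand. Compound 2 `COc1ccc(C(=O)/C=C/c2cccc(OCc3ccccc3)c2)cc1` gives 44300 nM in this assay, and the step of a 1.4-fold lower number from compound 1 to compound 2 (0.14 log units; within the scatter) stays within the scatter. Compound 3 `O=C(/C=C/c1cccc(OCc2ccccc2)c1)c1cccc(Br)c1` gives 6400 nM in this assay; the step of a 9.6-fold lower number from compound 1 to compound 3 (0.98 log units; beyond the scatter) lies beyond the scatter, as does a 6.9-fold lower number from compound 2 to compound 3 (0.84 log units; beyond the scatter). Compound 4 `O=C(/C=C/c1cccc(OCc2ccccc2)c1)c1ccc(Cl)c(Cl)c1Cl` differs from compound 1 in one place: 2,3,4-trichlorophenyl in place of 2-bromophenyl on a carbonyl carbon. The step of a 9.6-fold lower number from compound 1 to compound 3 (0.98 log units; beyond the scatter) bears on this, the entering 2,3,4-trichlorophenyl sharing substitution with the 3-bromophenyl of compound 3, while a 1.4-fold lower number from compound 1 to compound 2 (0.14 log units; within the scatter) shows a change on this ring need not move the number. A modest lowering is therefore expected, a 3.1-fold lower number from compound 1 to compound 4 (0.49 log units; beyond the scatter). For compound 4 the estimate is 20000 nM, range 6000 nM to 60000 nM.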

Compound 4, half-maximal inhibitory concentration: 2400 nM
The estimate for compound 4 lay 8.3-fold (0.92 log units) above the measured number; measured number outside the range, below it.
By their numbers in this assay, from the lowest: compound 4; then compound 3; then compounds 2 and 1 (each within the scatter of the next).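

On a carbonyl carbon, a ring carrying three chlorines reaches lower numbers than the earlier groups did: 2,3,4-trichlorophenyl gives a 26-fold lower number from compound 1 to compound 4 (1.41 log units; beyond the scatter) and an 18-fold lower number from compound 2 to compound 4 (1.27 log units; beyond the scatter), both large steps. It also passes 3-bromophenyl, with a 2.7-fold lower number from compound 3 to compound 4 (0.43 log units; beyond the scatter), so the lowest earlier number was no floor for this position. No measurement in hand offers a reason for these steps.

Whether all three chlorines are needed stays open, since no monochlorophenyl or dichlorophenyl ring is among the compounds shown. From the compounds shown here alone, how a phenyl ring bearing an amine or a carboxylic acid would read here is also open.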